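Hydroxy in Place of Amino on the Amide Side Chain

This account rests on a few compounds, and the source may have more. Where it says the series, first, only, none or still open, it means among the compounds named here.

Compound 1 `CCn1c(C(=O)N[C@@H](CC(=O)OC)C(=O)OC)ccc1C(CC)(CC)c1ccc(OCS(=O)(=O)c2ccccc2)c(C)c1` and compound 2 `CCn1c(C(=O)NCCN)ccc1C(CC)(CC)c1ccc(OCS(=O)(=O)c2ccccc2)c(C)c1` share a core and differ only in the group on an amide-type nitrogen. In a functional assay on PC-3 cells (Homo sapiens) for antiproliferative activity, read by MTT assay, with a stated time of 24 h (on this read-out lower numbers stand for stronger inhibition and higher numbers for weaker inhibition), compound 1 gives 6490 nM, and compound 2 gives 6890 nM. Going by the values given here, compound 2 therefore stands within the scatter of compound 1, the only other measured compound.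

Compound 3 `CCn1c(C(=O)NCCO)ccc1C(CC)(CC)c1ccc(OCS(=O)(=O)c2ccccc2)c(C)c1` makes one further change to compound 2: hydroxy in place of amino on a saturated chain carbon, two bonds along the chain from an amide-type nitrogen. This is hydroxy in place of amino on a saturated chain carbon, two bonds along the chain from an amide-type nitrogen, which turns 2-aminoethyl into 2-hydroxyethyl.

Among the compounds with values here, no measured step tests this exchange directly. Within the data shown here, the only step that bears on it is a 1.1-fold higher number from compound 1 to compound 2 (0.03 log units; within the scatter), where 2-aminoethyl took the place of 1,2-bis(methoxycarbonyl)ethyl. This single step is thin evidence, but it gives no reason to expect a shift in either direction, so no step beyond the scatter is expected in this assay. The expected change is a 1.0-fold lower number from compound 2 to compound 3 (0.01 log units; within the scatter). The estimated value for compound 3 is 6800 nM, with an expected range from 3400 nM to 13500 nM.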

Compound 3, half-maximal inhibitory concentration: 17700 nM
Compound 3: the middle estimate sits 2.6-fold (0.42 log units) below what was measured; the whole stated range lies below it.
By their numbers in this assay, from the lowest: compounds 1 and 2 (each within the scatter of the next); then compound 3.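

In this assay, this position proves sensitive to a very small exchange: hydroxy in place of amino on a saturated chain carbon, two bonds along the chain from an amide-type nitrogen, gives a 2.6-fold higher number from compound 2 to compound 3 (0.41 log units; beyond the scatter), a modest step, but a real one. The earlier pair showed no such separation, yet 2-hydroxyethyl also stands apart from the much larger 1,2-bis(methoxycarbonyl)ethyl group, with a 2.7-fold higher number from compound 1 to compound 3 (0.44 log units; beyond the scatter), so the side chain is not indifferent to what it carries. Nothing available explains why one heavy atom exchanged for another, with the same counts of hydrogen-bond donors and acceptors and no net charge on either group, should shift the number.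

The compounds shown leave open whether a methoxy group or a methylamino group in place of the amino group would stay with compound 2 or move towards compound 3. They also leave open whether a longer chain such as 3-hydroxypropyl would keep, widen or remove the step seen with 2-hydroxyethyl.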